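The source may report more compounds than this note shows. Statements on the series, on what has been measured and on what is new or still open speak of the compounds shown alone.

Three compounds have been measured in a functional assay on HeLa cells (Homo sapiens) for inhibition, read by MTT assay; a lower number here means a stronger inhibitor, a higher number a weaker inhibitor:

compound 1, `CC(C)(C)OC(=O)N1CCN(CC(=O)Nc2ccc(C(=O)/C=C/c3cn(Cc4ccc(Br)cc4)nn3)cc2)CC1`, with 18900 nM;
compound 2, `O=C(CN1CCN(c2ccc([N+](=O)[O-])cc2)CC1)Nc1ccc(C(=O)/C=C/c2cn(Cc3ccc(Br)cc3)nn2)cc1`, with 26600 nM;
compound 3, `CCCCCCCCCCn1cc(/C=C/C(=O)c2ccc(NC(=O)CN3CCN(C(=O)OC(C)(C)C)CC3)cc2)nn1`, with 30200 nM.

All three numbers lie within the scatter of one another, so no order among them can be drawn. Compound 2 is obtained from compound 1 by one change, (4-nitrophenyl in place of tert-butoxycarbonyl on an amine nitrogen in a ring), and this change gave a 1.4-fold higher number from compound 1 to compound 2 (0.15 log units; within the scatter). Compound 3 differs from compound 1 in another place, (nonyl in place of 4-bromophenyl on a saturated chain carbon bound to an aromatic nitrogen), and that change gave a 1.6-fold higher number from compound 1 to compound 3 (0.20 log units; within the scatter).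

Compound 4, `CCCCCCCCCCn1cc(/C=C/C(=O)c2ccc(NC(=O)CN3CCN(c4ccc([N+](=O)[O-])cc4)CC3)cc2)nn1`, has not yet been measured in this assay. It is related to compound 3 in the same way that compound 2 is related to compound 1: the change is 4-nitrophenyl in place of tert-butoxycarbonyl on an amine nitrogen in a ring, and the place is described in the same words for both pairs, so this is the same change made on the core of compound 3 instead of the core of compound 1. Going by the values given here, the only precedent for it is the step from compound 1 to compound 2, which stayed within the scatter, and the two cores are themselves separated by a step that stayed within the scatter. On that basis the step is expected to be about a 1.4-fold higher number from compound 3 to compound 4 (0.14 log units; within the scatter). That expectation rests on a 1.4-fold higher number from compound 1 to compound 2 (0.15 log units; within the scatter) applied to the number of compound 3, 30200 nM. Compound 4 is therefore estimated to give 42000 nM in this assay, with a likely range from 15000 nM to 120000 nM.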

Compound 4, half-maximal inhibitory concentration: 65900 nM
For compound 4 the middle estimate is 1.6-fold (0.20 log units) below the measured one; the range from low to high includes it.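

In this assay, 4-nitrophenyl in place of tert-butoxycarbonyl on an amine nitrogen in a ring gave a 2.2-fold higher number from compound 3 to compound 4 (0.34 log units; beyond the scatter), and this step cannot be told apart from the one made with the same change on the core of compound 1: the same change on two cores in this assay, a 1.4-fold higher number (0.15 log units; within the scatter) from compound 1 to compound 2 and a 2.2-fold higher number (0.34 log units; beyond the scatter) from compound 3 to compound 4, 1.6-fold (0.19 log units) apart, within the scatter of two such steps. Nonyl in place of 4-bromophenyl gave a 2.5-fold higher number from compound 2 to compound 4 (0.39 log units; beyond the scatter), and this step likewise cannot be told apart from its counterpart: the same change on two cores in this assay, a 1.6-fold higher number (0.20 log units; within the scatter) from compound 1 to compound 3 and a 2.5-fold higher number (0.39 log units; beyond the scatter) from compound 2 to compound 4, 1.6-fold (0.19 log units) apart, within the scatter of two such steps. Both changes thus carried from one core to the other without a measurable difference in step size, but this does not show that the steps are identical or that the same would hold on other cores, since each comparison rests on a single pair of steps among the same four compounds.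

As far as these compounds go, it remains open whether other groups on the amine nitrogen in the ring, such as an acetyl, a benzyl or a plain hydrogen, would follow the same course on both cores. From the compounds shown here alone, it is also open how a shorter chain or a 4-fluorophenyl in place of the nonyl or the 4-bromophenyl would behave alongside these changes.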